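Carbonyl substituent variation and Caco-2 permeability

The source may report more compounds than this note shows. Statements on the series, on what has been measured and on what is new or still open speak of the compounds shown alone.

Three compounds share one core and differ only in the group attached to a carbonyl carbon. Compound 1 `Cn1cncc1CN1CC(N(CC2CCN(C(=O)C(C)(C)C)CC2)S(=O)(=O)c2ccccn2)Cc2cc(C#N)ccc21` carries tert-butyl there, compound 2 `Cn1cncc1CN1CC(N(CC2CCN(C(=O)N3CCCCC3)CC2)S(=O)(=O)c2ccccn2)Cc2cc(C#N)ccc21` carries piperidin-1-yl, and compound 3 `Cn1cncc1CN1CC(N(CC2CCN(C(=O)C3CCCC3)CC2)S(=O)(=O)c2ccccn2)Cc2cc(C#N)ccc21` carries cyclopentyl. In an ADME assay on Caco-2 cells (Homo sapiens) for permeability, in the apical to basolateral direction (on this read-out higher numbers stand for higher permeability and lower numbers for lower permeability), compound 1 gives 0.5 10^-6 cm/s, compound 2 gives 0.6 10^-6 cm/s and compound 3 gives 0.5 10^-6 cm/s. The steps between them are all small: a 1.2-fold higher number from compound 1 to compound 2 (0.08 log units; within the scatter), no change at the digits printed from compound 1 to compound 3 (within the scatter) and a 1.2-fold lower number from compound 2 to compound 3 (0.08 log units; within the scatter). Compound 3 therefore stands level with compound 1, the two together forming the lower pair of the three numbers, and compound 2 is its furthest neighbour while still lying within the scatter.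

Compound 4 `Cn1cncc1CN1CC(N(CC2CCN(C(=O)c3cccs3)CC2)S(=O)(=O)c2ccccn2)Cc2cc(C#N)ccc21` alters the same position once more: thiophen-2-yl in place of cyclopentyl on a carbonyl carbon. Within the data shown here, the steps that bear on this are the three exchanges at the carbonyl carbon already measured, none of which moved the number beyond the scatter despite swapping branched, cyclic and nitrogen-containing groups. On that basis the expected step is no change at the digits printed from compound 3 to compound 4 (within the scatter), with no direction beyond the scatter favoured. Compound 4 is accordingly estimated at 0.5 10^-6 cm/s in this assay, with a range from 0.3 10^-6 cm/s to 0.9 10^-6 cm/s.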

Compound 4, apparent permeability: 0.5 10^-6 cm/s
Compound 4: middle estimate and measured number agree at the digits printed; low and high end bracket the measured number.
By their numbers in this assay, from the lowest: compounds 1, 3, 4 and 2 (each within the scatter of the next).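

Thiophen-2-yl brings the first aromatic ring to this carbonyl carbon, with a sulfur atom and one hydrogen-bond acceptor in place of the all-carbon, non-aromatic cyclopentyl, and in this assay this exchange gives no change at the digits printed from compound 3 to compound 4 (within the scatter). The comparisons with the other two groups read the same way, with thiophen-2-yl in place of piperidin-1-yl giving a 1.2-fold lower number from compound 2 to compound 4 (0.08 log units; within the scatter) and thiophen-2-yl in place of tert-butyl giving no change at the digits printed from compound 1 to compound 4 (within the scatter). Among these four compounds, then, the exchanges at this position now span aromatic as well as non-aromatic rings, and every one stays within the scatter, although no supporting data are available to explain that result.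

Still open, going by these compounds, is whether a group carrying a primary amine or a carboxylic acid at this carbonyl carbon would take the number in this assay beyond the scatter. On these data alone, it is equally open whether changes elsewhere on the shared core, rather than at this carbonyl carbon, would do so.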